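Side-chain changes on a shared core and the tail flick response

The compounds below may be only part of what the source reports. "The series", "measured", "known", "first", "only" and "open" are said of these compounds alone.

Three compounds built on one core have been examined: compound 1 `O=C(CN(c1nc(Cl)nc2[nH]cnc12)C1CC1)N[C@@H](CC(=O)OCc1ccccc1)C(=O)OCc1ccccc1`, compound 2 `O=C(CN(c1nc(Cl)nc2[nH]cnc12)C1CC1)N[C@@H](CCC(=O)OCc1ccccc1)C(=O)OCc1ccccc1` and compound 3 `CC[C@H](C)[C@H](NC(=O)CN(c1nc(Cl)nc2[nH]cnc12)C1CC1)C(=O)OCc1ccccc1`. In a functional assay on the whole organism (Tail, strain ICR) with Mus musculus as the target, in the tail flick test, with a stated time of 150 min, at a dose of 25 umol/kg by the oral route (a lower number here means a weaker effect, a higher number a stronger effect of the compound at the dose given), compound 1 gives 6.68%, compound 2 gives 44.5% and compound 3 gives 6.9%. Compound 3 thus stands second highest of the three numbers, with compound 1 within the scatter of it and compound 2 far above it, as the step of a number 37.6 percentage points lower from compound 2 to compound 3 (beyond the scatter) shows. The change a number 37.8 percentage points higher from compound 1 to compound 2 (beyond the scatter) was large as well, while a number 0.2 percentage points higher from compound 1 to compound 3 (within the scatter) stayed within the scatter.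

Compound 4 `NC(=O)CC[C@H](NC(=O)CN(c1nc(Cl)nc2[nH]cnc12)C1CC1)C(=O)OCc1ccccc1` has not yet been measured. It differs from compound 3 in one place: 2-carbamoylethyl in place of sec-butyl on a saturated chain carbon bound to an amide-type nitrogen and a carbonyl carbon. The step that bears most on this is a number 37.6 percentage points lower from compound 2 to compound 3 (beyond the scatter), since compound 2 likewise carries a longer chain on that carbon, ending in a carbonyl, and sits far higher than compound 3. For the measured compounds named here, the entering 2-carbamoylethyl chain is shorter than the one in compound 2 and ends in an amide rather than an ester, so the author expects only part of that gain to return. Compound 4 is therefore estimated at 20%, in a range from 5% to 45%. This expected step of a number 13.1 percentage points higher from compound 3 to compound 4 (beyond the scatter) is a rise, though a modest one.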

Compound 4, a percentage reported as activity, at one dose (the size of the read-out at that dose, not a potency): 31.1%
Compound 4: middle estimate off by 11.1 percentage points, on the low side, within the range that was stated.
By their numbers in this assay, from the lowest: compounds 1 and 3 (each within the scatter of the next); then compound 4; then compound 2.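

For the compounds shown here, until this result, the only side chain on the saturated chain carbon bound to an amide-type nitrogen and a carbonyl carbon that had raised the response in this assay was the 2-(benzyloxycarbonyl)ethyl chain of compound 2, but the 2-carbamoylethyl chain, which holds no ring, also raises it, with a number 24.2 percentage points higher from compound 3 to compound 4 (beyond the scatter). The end of the chain still matters, as amino in place of benzyloxy on a carbonyl carbon gives a number 13.4 percentage points lower from compound 2 to compound 4 (beyond the scatter), so the amide keeps part of the response seen with the ester but not all of it. The benzyl ester is also not enough alone, as compound 1 carries one on a shorter chain and stays low, with a number 24.4 percentage points higher from compound 1 to compound 4 (beyond the scatter).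

Nothing available here accounts for these differences. Going by these compounds, it remains open how the response would change if the chain at this position ended in a carboxylic acid or an amine, or if a longer chain carried the same terminal amide, and whether the carbamoylmethyl chain would stay as low as its ester counterpart in compound 1.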